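The compounds below may be only part of what the source reports. "The series", "measured", "known", "first", "only" and "open" are said of these compounds alone.

In a functional assay on PC-3 cells (Homo sapiens) for cytotoxicity, read by MTT assay (a lower number here means a stronger inhibitor, a higher number a weaker inhibitor), compound 1 `COc1ccc2cc([C@H](C)c3nnc(SCc4ccc(Cl)cc4)n3-c3ccc(F)cc3)ccc2c1` gives <= 400000 nM, and this is a limit of the assay, not a number. Two relatives on the shared core have numbers: compound 2 `COc1ccc2cc([C@H](C)c3nnc(SCc4c(C)cc(C)cc4C)n3-c3cccc(Cl)c3)ccc2c1` gives 16300 nM and compound 3 `COc1cccc(CSc2nnc([C@@H](C)c3ccc4cc(OC)ccc4c3)n2-c2ccc(Cl)cc2)c1` gives 138000 nM. Going by the values given here, neither pairs with compound 1 through a single change, so no measured step bears directly on what follows. Compound 4 `COc1ccc2cc([C@H](C)c3nnc(SCc4ccc(C)cc4)n3-c3ccc(F)cc3)ccc2c1` keeps the core of compound 1 and swaps one group: methyl in place of chloro on an aromatic carbon. This is methyl in place of chloro on an aromatic carbon, turning 4-chlorobenzyl into 4-methylbenzyl. With compound 3 at 138000 nM as the nearest guide, the expected change is a step that the limit leaves unreadable from compound 1 to compound 4, a modest move toward a lower number. Compound 4 is estimated at 120000 nM, with an expected range of 30000 nM to 400000 nM.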

Compound 4, half-maximal inhibitory concentration: 229000 nM
For compound 4 the middle estimate is 1.9-fold (0.28 log units) below the measured one; the measured number falls inside the stated range.
By their numbers in this assay, from the lowest: compound 2; then compounds 3 and 4 (each within the scatter of the next).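

Going by these compounds alone, no step from compound 1 to compound 4 can be read, because compound 1 carries only a limit of the assay: the limit of <= 400000 nM in this assay, at which 1 of the 4 values shown sits. The compounds shown leave open how methyl in place of chloro shifts cytotoxicity on this core.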